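Shortening the piperidine substituents while lengthening the linker

The compounds below may be only part of what the source reports. "The series", "measured", "known", "first", "only" and "open" are said of these compounds alone.

Measured compounds:
- Compound 1, `CC[C@@H]1C[C@H](CC)CN(CCCNC(=O)C2CCN(Cc3nc(-c4ccccc4C)oc3C)CC2)C1`: 1270 10^-6 cm/s
- Compound 2, `Cc1oc(-c2ccc(F)cc2)nc1CN1CCC(C(=O)NCCCN2C[C@H](C)C[C@H](C)C2)CC1`: "not determined" (no result reported)
- Compound 3, `CC[C@@H]1C[C@H](CC)CN(CCCNC(=O)C2CCN(Cc3nc(-c4c(F)cccc4F)oc3C)CC2)C1`: 130 10^-6 cm/s

Three compounds share a core in which a substituted oxazole is joined through a piperidine amide to a chain ending in a dialkylpiperidine. In a physicochemical assay for permeability, using PAMPA (a higher number here means that the compound crosses the layer faster, a lower number that the compound crosses the layer more slowly), compound 1 gives 1270 10^-6 cm/s, the highest of the two numbers reported. For compound 2 no result was reported in this assay. Within the data shown here, compound 3, which carries a 2,6-difluorophenyl in place of the 2-methylphenyl, gives 130 10^-6 cm/s in this assay; the step of a 9.8-fold lower number from compound 1 to compound 3 (0.99 log units; beyond the scatter) is the only measured step and concerns the aryl group on the oxazole, not the chain end.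

Compound 4, `Cc1ccccc1-c1nc(CN2CCC(C(=O)NCCCCN3C[C@H](C)C[C@H](C)C3)CC2)c(C)o1`, differs from compound 1 at the other end of the molecule: (3,5-dimethylpiperidin-1-yl)methyl in place of 3,5-diethylpiperidin-1-yl on a saturated chain carbon, three bonds along the chain from an amide-type nitrogen. Among the measured compounds shown here, no measured step touches this part of the core, so the account of compound 3 cannot be carried over; the change removes one carbon overall and keeps both stereocentres, the donor and acceptor count unchanged. A step of no size beyond the scatter, or at most a small decrease, is therefore expected. Compound 4 is estimated at 900 10^-6 cm/s in this assay, within 400 10^-6 cm/s to 2000 10^-6 cm/s, meaning an expected step of a 1.4-fold lower number from compound 1 to compound 4 (0.15 log units; within the scatter).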

Compound 4, apparent permeability: 288 10^-6 cm/s
The estimate for compound 4 lay 3.1-fold (0.49 log units) above the measured number; the whole stated range lies above it.
By their numbers in this assay, from the lowest: compound 3; then compound 4; then compound 1.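

The chain end of the core of compound 1 proves to be a place where a single change counts: in this assay the step of a 4.4-fold lower number from compound 1 to compound 4 (0.64 log units; beyond the scatter) goes beyond the scatter, so the aryl group on the oxazole is no longer the only position shown to matter. The change is a combined one, since (3,5-dimethylpiperidin-1-yl)methyl replaces 3,5-diethylpiperidin-1-yl, shortening the ring substituents and lengthening the linker while both groups keep a six-membered non-aromatic ring and defined stereocentres, and the step cannot divide its size between these two parts. Nothing available bears on why the number falls, so the step stands without an explanation.

The compounds shown leave open whether the ethyl-to-methyl change or the longer chain carries the step, as none pairs the 2-methylphenyl with 3,5-dimethylpiperidin-1-yl on the shorter chain or 3,5-diethylpiperidin-1-yl on the longer one. They also leave open how the number responds to a chain end with a different ring, such as a morpholine, or to a still longer chain.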